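The compounds below may be only part of what the source reports. "The series", "measured", "known", "first", "only" and "open" are said of these compounds alone.

Measured so far in a functional assay for inhibition of sodium/hydrogen exchanger (Oryctolagus cuniculus); on this read-out lower numbers stand for stronger inhibition and higher numbers for weaker inhibition:
compound 1, `Cc1cc(-c2cc(Cl)cc(Cl)c2)c(S(C)(=O)=O)cc1C(=O)N=C(N)N`, gives 130 nM;
compound 2, `Cc1cc(Sc2ccncc2)c(S(C)(=O)=O)cc1C(=O)N=C(N)N`, gives 13 nM;
compound 3, `Cc1cc(OC2CCCCC2)c(S(C)(=O)=O)cc1C(=O)N=C(N)N`, gives 37 nM.

Compound 3 holds the middle place of the three: the step of a 2.8-fold higher number from compound 2 to compound 3 (0.45 log units; beyond the scatter) sets it behind compound 2, while the step of a 3.5-fold lower number from compound 1 to compound 3 (0.55 log units; beyond the scatter) sets it ahead of compound 1. Compound 4, `Cc1cc(Nc2ncccn2)c(S(C)(=O)=O)cc1C(=O)N=C(N)N`, differs from compound 3 in one place: (pyrimidin-2-yl)amino in place of cyclohexyloxy on an aromatic carbon. Two measured steps exchange the group on this same aromatic carbon, a 10-fold lower number from compound 1 to compound 2 (1.00 log units; beyond the scatter) and a 2.8-fold higher number from compound 2 to compound 3 (0.45 log units; beyond the scatter), both modest yet beyond the scatter, and the (pyridin-4-yl)sulfanyl group of compound 2 gave the lowest number. The entering (pyrimidin-2-yl)amino group likewise carries one six-membered aromatic ring with 2 hetero atoms, so a modest step toward a lower number in this assay is expected, a 1.9-fold lower number from compound 3 to compound 4 (0.27 log units; within the scatter). Compound 4 is therefore estimated at 20 nM, in the range 8 nM to 60 nM.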

Compound 4, half-maximal inhibitory concentration: 8.3 nM
The estimate for compound 4 lay 2.4-fold (0.38 log units) above the measured number; the measured number falls inside the stated range.
By their numbers in this assay, from the lowest: compounds 4 and 2 (each within the scatter of the next); then compound 3; then compound 1.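

Compound 4 shows that in this assay this aromatic carbon, ortho to a methylsulfonyl group, also accepts an aromatic ring attached through an amino link: the change gives a 4.5-fold lower number from compound 3 to compound 4 (0.65 log units; beyond the scatter) and, against the 3,5-dichlorophenyl group, a 16-fold lower number from compound 1 to compound 4 (1.19 log units; beyond the scatter). The exchange for the (pyridin-4-yl)sulfanyl group gives a 1.6-fold lower number from compound 2 to compound 4 (0.19 log units; within the scatter), so two different linked aromatic rings with hetero atoms are not separated here. Nothing measured here accounts for these differences.

It remains open whether the amino link or the pyrimidine ring carries the change, since a pyrimidin-2-yl group joined through sulfur, or a plain phenylamino group, is not among the compounds shown. Going by these compounds, how a small group such as a primary amine or a carboxylic acid would behave on this carbon also remains open.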